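Swapping a ring-bound group at the chain carbon of compound 2

The source may hold more compounds than are shown below. What is called first, only, known or untested is meant among the compounds shown, and "the series" means these compounds.

Measured so far:
compound 1, `CC(C)[C@H](C[C@H]1OC(=O)NC1=O)c1ccc(-c2ccc3cccc(F)c3c2)[nH]c1=O`, 24400 nM;
compound 2, `C/C(=C1/OC(=O)NC1=O)C(c1ccc(-c2ccc3cccc(F)c3c2)[nH]c1=O)C(C)C`, 12700 nM.

In a physicochemical assay for solubility, measured as kinetic solubility, at pH 2 (on this read-out lower numbers stand for lower solubility and higher numbers for higher solubility), compound 2 gives 12700 nM, the lower of the two numbers, while compound 1 gives 24400 nM; the two values lie within the scatter of each other, so they cannot be told apart.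

Compound 3, `CC(C)C(c1ccc(-c2ccc3cccc(F)c3c2)[nH]c1=O)C1C(=O)NC(=O)N1C`, has not yet been measured in this assay. Compared with compound 2 it carries a group of 8 heavy atoms (4 carbon, 2 nitrogen, 2 oxygen; one five-membered non-aromatic ring with 2 hetero atoms) in place of a group of 9 heavy atoms (5 carbon, 1 nitrogen, 3 oxygen; one five-membered non-aromatic ring with 2 hetero atoms), on a saturated chain carbon bound to an aromatic carbon and a saturated chain carbon. Going by the values given here, no step between two measured compounds mirrors this change, so there is no measured guide for its size. Both measured values sit close together, and the exchange keeps one five-membered ring with two hetero atoms and one hydrogen-bond donor, so in this assay a step from compound 2 to compound 3 of a 1.2-fold higher number from compound 2 to compound 3 (0.07 log units; within the scatter) is expected, that is, no change beyond the scatter. Compound 3 is therefore estimated at 15000 nM, with a range from 6000 nM to 40000 nM.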

Compound 3, solubility: 13600 nM
Beside the measured number, compound 3's estimate is 1.1-fold (0.04 log units) above it; measured number inside the range.
By their numbers in this assay, from the lowest: compounds 2, 3 and 1 (each within the scatter of the next).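

In this assay the exchange of the leaving group for 3-methyl-2,5-dioxoimidazolidin-4-yl, on a saturated chain carbon bound to an aromatic carbon and a saturated chain carbon, gives a 1.1-fold higher number from compound 2 to compound 3 (0.03 log units; within the scatter) and so leaves the two compounds indistinguishable. The entering ring holds 2 nitrogen and 2 oxygen atoms where the leaving one holds 1 nitrogen and 3 oxygen, and it has 2 double bonds outside aromatic rings rather than 3, yet on this single pair these differences produce no step beyond the scatter. Nothing measured here bears on the reason for this result.

On these data alone, whether a group without a ring at this carbon, such as a carboxylic acid or an amine, would give a step beyond the scatter remains open. One pair also cannot show whether the same exchange would read alike on a different core.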